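The source may report more compounds than this note shows. Statements on the series, on what has been measured and on what is new or still open speak of the compounds shown alone.

Measured so far in the series:
compound 1 `Nc1cc(N)c2nc(-c3ccccc3)c(Oc3ccc(Cl)c(Cl)c3)nc2c1` — < 100000 nM
compound 2 `COc1ccc(CNc2nc3cc(N)cc(N)c3nc2-c2ccccc2)cc1OC` — 81300 nM
compound 3 `COc1cc(CNc2nc3cc(N)cc(N)c3nc2-c2ccccc2)cc(OC)c1OC` — 23400 nM

All three were run in a functional assay on ACHN cells (Homo sapiens) for inhibition, read by sulforhodamine B assay, with a stated time of 48 h; a higher number here means that more compound is tolerated, a lower number that less compound is tolerated. For compound 1 this assay reports only a limit, < 100000 nM, and no number. Of the two numbers, compound 2 stands highest, with compound 3 nearest to it. Within the data shown here, the single step measured between them, a 3.5-fold lower number from compound 2 to compound 3 (0.54 log units; beyond the scatter), is the only one.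

Compound 4 `Nc1cc(N)c2nc(-c3ccccc3)c(NCc3ccc(F)cc3)nc2c1` differs from compound 2 by 4-fluorophenyl in place of 3,4-dimethoxyphenyl on a saturated chain carbon bound to a nitrogen on an aromatic ring. Among the measured compounds shown here, no measured step exchanges this whole ring; the step from compound 2 to compound 3 bears on it only indirectly, since there an added methoxy gave a lower number, whereas here both methoxy groups leave and a fluorine enters. On that thin basis the number for compound 4 is expected to sit at or somewhat above that of compound 2, an expected step of a 1.4-fold higher number from compound 2 to compound 4 (0.13 log units; within the scatter). The estimate for compound 4 in this assay is 110000 nM, between 35000 nM and 300000 nM, with a real chance that only a limit is reported.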

Compound 4, concentration lethal to 50% of the cells: 5620 nM
Estimate against measurement, compound 4: 20-fold (1.29 log units) above; the measured number lies below the stated range.
By their numbers in this assay, from the lowest: compound 4; then compound 3; then compound 2.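

In this assay, exchanging the whole ring on the saturated chain carbon gives a 14-fold lower number from compound 2 to compound 4 (1.16 log units; beyond the scatter) and is larger than the step of a 3.5-fold lower number from compound 2 to compound 3 (0.54 log units; beyond the scatter) on the same ring. The number therefore does not follow the count of methoxy groups: relative to compound 2, both adding a methoxy and replacing 3,4-dimethoxyphenyl with 4-fluorophenyl lower it. Compound 1 carries only a limit, so its step to compound 4 cannot be read: the limit of < 100000 nM in this assay, at which 1 of the 4 values shown sits.

Still open, from the compounds shown here alone, is how much of the larger step belongs to the fluorine and how much to the loss of the methoxy groups, a question that unsubstituted phenyl or 4-methoxyphenyl at this place would separate. Also open, going by these compounds, is whether 4-chlorophenyl or a longer chain between the nitrogen and the ring would carry the trend further.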